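Cinnamamide Series: Trimethoxyphenyl to Fluorophenyl Swap

A few compounds are considered here, and "the series" means these few. Any claim that something is new, unique, unknown or untested is made for them only; others in the source may bear on it.

Compound 1 `COc1ccc(C(=O)c2cc(OC)c(OC)c(OC)c2)cc1NC(=O)/C=C/c1cccc(OC(F)(F)F)c1` and compound 2 `COc1cc(C(=O)c2cc(OC)c(OC)c(OC)c2)cc(NC(=O)/C=C/c2cc(OC)c(OC)c(OC)c2)c1OC` share the benzophenone amide core. In a functional assay on COLO 205 cells (Homo sapiens) for cytotoxicity, read by MTT assay, with a stated time of 72 h (on this read-out lower numbers stand for stronger inhibition and higher numbers for weaker inhibition), compound 2 gives 5300 nM; in this assay compound 1 gives 7900 nM, a gap within the usual scatter, so the two stand together on this read-out. Compound 3 `COc1cc(C(=O)c2cc(OC)c(OC)c(OC)c2)cc(NC(=O)/C=C/c2ccc(F)cc2)c1OC` is the next entry: 4-fluorophenyl in place of 3,4,5-trimethoxyphenyl on a double-bonded chain carbon bound to a double-bonded chain carbon. Among the measured compounds shown here, no measured pair shows this change, so its effect cannot be read from the data. A modest weakening step is expected, a 1.3-fold higher number from compound 2 to compound 3 (0.12 log units; within the scatter), possibly not beyond the scatter. Compound 3 is therefore expected near 7000 nM in this assay, within 2500 nM to 20000 nM.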

Compound 3, half-maximal inhibitory concentration: 3100 nM
The estimate for compound 3 lay 2.3-fold (0.35 log units) above the measured number, and the stated range covers the measured number.
By their numbers in this assay, from the lowest: compounds 3, 2 and 1 (each within the scatter of the next, the first and the last beyond it).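

Among the compounds shown here, on the double-bonded chain carbon, 4-fluorophenyl in place of 3,4,5-trimethoxyphenyl gives a 1.7-fold lower number from compound 2 to compound 3 (0.23 log units; within the scatter) in this assay, the first single-place comparison. At this place, the 7-heavy-atom group therefore stands level with the 12-heavy-atom group, and the hydrogen-bond acceptors of 3,4,5-trimethoxyphenyl are not needed to hold this level. No evidence bears on the reason for this result.

Still open, going by these compounds, is whether an amine, a carboxylic acid or a longer chain at this place would give a step beyond the scatter. On these data alone, whether chlorine could stand in for the fluorine of 4-fluorophenyl is also open.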